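Swapping methoxy for cyano on compound 2

A few compounds are considered here, and "the series" means these few. Any claim that something is new, unique, unknown or untested is made for them only; others in the source may bear on it.

Of the compounds shown here, three have so far been tested in a functional assay on MT4 cells (Homo sapiens) for cytotoxicity; a lower number here means a stronger inhibitor, a higher number a weaker inhibitor. Compound 1 (`N#Cc1c(N)cccc1Sc1ccc(Cl)cc1`) gives 113000 nM, and compound 3 (`N#Cc1c(N)cccc1[S+]([O-])c1ccccc1Br`) gives 168000 nM, two values within the usual scatter of each other. Compound 2 (`COc1cccc([S+]([O-])c2cccc(N)c2C#N)c1`) stands at > 80000 nM, which is a limit of the assay and not a number.

Compound 4 (`N#Cc1cccc([S+]([O-])c2cccc(N)c2C#N)c1`) differs from compound 2 in one place: cyano in place of methoxy on an aromatic carbon. Put simply, this is cyano in place of methoxy on an aromatic carbon, meta to a large group. Going by the values given here, no pair of tested compounds shows a step of this kind, so the expectation rests on the overall level of the series, with compound 1 at 113000 nM and compound 3 at 168000 nM. In this assay, no step beyond the scatter is expected, and no direction can be favoured. The expected step, a step that the limit leaves unreadable from compound 2 to compound 4, is therefore small. The estimate for compound 4 is 110000 nM, with an expected range of 50000 nM to 240000 nM.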

Compound 4, half-maximal inhibitory concentration: > 200000 nM
Compound 4 was reported as a limit; the forecaster's own chance of this, stated with the estimate: 45%; middle value at least 1.8-fold (0.25 log units) from the limit.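

In this assay compound 4 gives > 200000 nM and this is a limit of the assay, not a number. Going by these compounds alone, compound 2 gives > 80000 nM which is also a limit, so no step from compound 2 to compound 4 can be read. The compounds shown leave open whether cyano in place of methoxy on an aromatic carbon changes the read-out at all, and if so, in which direction and by how much.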